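The source may hold more compounds than are shown below. What is called first, only, known or untested is meant among the compounds shown, and "the series" means these compounds.

Measured compounds in this study:

Compound 1, `Cc1ccc(S(=O)(=O)Oc2ccccc2/C=C(\C#N)C(=O)Nc2nnc(Cc3ccc(F)cc3)s2)cc1`: 16%
Compound 2, `COc1ccc(S(=O)(=O)Oc2ccccc2/C=C(\C#N)C(=O)Nc2nnc(Cc3ccc(F)cc3)s2)cc1`: 20%
Compound 3, `Cc1ccc(S(=O)(=O)Oc2ccccc2/C=C(\C#N)C(=O)Nc2nnc(Cc3cccc(F)c3)s2)cc1`: 9%

All three were tested in an ADME assay on HEK-293T cells (Homo sapiens) for inhibition, read by CCK-8 assay, with a stated time of 48 h, tested at 20 uM; a higher number here means more inhibition of growth at the concentration tested, a lower number less inhibition of growth. Compound 2 differs from compound 1 by methoxy in place of methyl on an aromatic carbon, and this change gave a number 4 percentage points higher from compound 1 to compound 2 (within the scatter). Compound 3 differs from compound 1 in its core by 3-fluorophenyl in place of 4-fluorophenyl on a saturated chain carbon bound to an aromatic carbon, a change that gave a number 7 percentage points lower from compound 1 to compound 3 (within the scatter). Compound 3 holds the lowest of the three numbers, yet its gap to compound 1 stays within the scatter, and only its gap to compound 2 lies beyond it, so no ordering among the three can be claimed with confidence.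

Compound 4 `COc1ccc(S(=O)(=O)Oc2ccccc2/C=C(\C#N)C(=O)Nc2nnc(Cc3cccc(F)c3)s2)cc1` has not yet been measured in this assay. It differs from compound 3 by methoxy in place of methyl on an aromatic carbon. This is the same change that separates compound 2 from compound 1, now made on the core of compound 3, and the surroundings of the place are the same in both cases. The step from compound 3 to compound 4 is estimated at a number 4 percentage points higher from compound 3 to compound 4 (within the scatter), set beside the earlier step because that earlier step gave a number 4 percentage points higher from compound 1 to compound 2 (within the scatter). For the measured compounds named here, only a single measured instance of this change exists, so the expectation rests on that one step alone and on the modest value of compound 3. Compound 4 is expected to give 13% in this assay, with a range from 3% to 24%.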

Compound 4, percent growth inhibition at one concentration: 29%
Beside the measured number, compound 4's estimate is 16 percentage points below it; the whole stated range lies below it.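

In this assay, methoxy in place of methyl on the aromatic carbon gave a number 20 percentage points higher from compound 3 to compound 4 (beyond the scatter), and this step does not match its counterpart on the core of compound 1: the same change on two cores in this assay, a number 4 percentage points higher (within the scatter) from compound 1 to compound 2 and a number 20 percentage points higher (beyond the scatter) from compound 3 to compound 4, 16 percentage points apart, beyond the scatter of two such steps. The change from 4-fluorophenyl to 3-fluorophenyl, read on the methoxy side of the series, gave a number 9 percentage points higher from compound 2 to compound 4 (within the scatter), and it likewise fails to carry over from the methyl side: the same change on two cores in this assay, a number 7 percentage points lower (within the scatter) from compound 1 to compound 3 and a number 9 percentage points higher (within the scatter) from compound 2 to compound 4, 16 percentage points apart, beyond the scatter of two such steps. Across these four compounds, then, the size of each step depends on the group present at the other place, so neither change can be carried to the other core as a fixed increment, although the data show neither why this happens nor whether it would hold on any further core.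

The compounds shown leave open whether an ethoxy group, a chlorine atom or an amine in place of the methoxy would show the same dependence on the fluorophenyl group. They also leave open whether a chlorophenyl or an unsubstituted phenyl group on the saturated chain carbon would pair with methoxy as 3-fluorophenyl does in compound 4.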